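The source may report more compounds than this note shows. Statements on the series, on what has been measured and on what is new or still open speak of the compounds shown alone.

Compound 2 `COc1ccc(-c2cc3ccccc3nc2/C=C/C(=O)c2ccc(O)cc2)cc1` is one of two compounds tested in a functional assay on A549 cells (Homo sapiens) for antiproliferative activity, read by XTT assay, with a stated time of 72 h (a higher number here means a weaker inhibitor, a lower number a stronger inhibitor), and in that assay compound 2 gives 7440 nM. For the measured compounds named here, its only partner is compound 1 `COc1ccc(-c2cc3ccccc3nc2/C=C/C(=O)c2ccc(F)cc2)cc1`, which in this assay gives 8320 nM; the two numbers sit within the usual scatter of each other, so neither can be called the stronger inhibitor.

Compound 3 `COc1ccc(-c2cc3ccccc3nc2/C=C/C(=O)c2c(OC)cccc2OC)cc1` differs from compound 2 in that (2,6-dimethoxyphenyl in place of 4-hydroxyphenyl on a carbonyl carbon). Going by the values given here, the single measured step, a 1.1-fold lower number from compound 1 to compound 2 (0.05 log units; within the scatter), also changed the ring attached to the carbonyl carbon, but it swapped only one small group and produced no shift beyond the scatter. Because of a 1.1-fold lower number from compound 1 to compound 2 (0.05 log units; within the scatter) the change to compound 3 is expected to move this assay little, if at all, and the step of a 1.1-fold higher number from compound 2 to compound 3 (0.03 log units; within the scatter) is estimated to stay within the scatter. Compound 3 is therefore expected to give about 8000 nM, with a plausible range from 3000 nM to 25000 nM.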

Compound 3, half-maximal inhibitory concentration: 7410 nM
The estimate for compound 3 lay 1.1-fold (0.03 log units) above the measured number; the measured number falls inside the stated range.
By their numbers in this assay, from the lowest: compounds 3, 2 and 1 (each within the scatter of the next).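

Exchanging the whole ring on the carbonyl carbon, not just one small group on it, still produces no readable change in this assay: the result is a 1.0-fold lower number from compound 2 to compound 3 (0.00 log units; within the scatter), and the comparison with the fluorinated compound is a 1.1-fold lower number from compound 1 to compound 3 (0.05 log units; within the scatter). The 2,6-dimethoxyphenyl group has 10 heavy atoms and 0 hydrogen-bond donors, against 7 heavy atoms and 1 donor for 4-hydroxyphenyl, so this position tolerates a larger difference than the earlier pair could show. Nothing available here explains why the number holds steady.

As far as these compounds go, all three groups at this position are substituted phenyl rings, so it remains open whether an amine, a carboxylic acid or a longer chain there would move the number beyond the scatter. From the compounds shown here alone, whether changes elsewhere on the shared core would matter more also remains open.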